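Propanoyl in Place of Acetyl on the Bromo Analogue

The compounds below may be only part of what the source reports. "The series", "measured", "known", "first", "only" and "open" are said of these compounds alone.

Compound 3 `CC(=O)NCCCc1cccc(Br)c1` gives 852 nM in an assay for binding affinity to melatonin receptor (Gallus gallus); a lower number here means a stronger inhibitor, a higher number a weaker inhibitor. Among the three compounds measured, it stands second highest: compound 2 `CCC(=O)NCCCc1cccc(F)c1`, at 740 nM, sits within the scatter of it, while compound 1 `CC(=O)NCCCc1cccc(F)c1`, with 1920 nM, lies beyond it, as a 2.3-fold lower number from compound 1 to compound 3 (0.35 log units; beyond the scatter) shows. Compound 4 `CCC(=O)NCCCc1cccc(Br)c1` differs from compound 3 by methyl in place of hydrogen on a saturated chain carbon bound to a carbonyl carbon. Among the measured compounds shown here, the only measured step of the same kind is a 2.6-fold lower number from compound 1 to compound 2 (0.41 log units; beyond the scatter), a modest drop in the number that exceeds the scatter. The change from fluoro to bromo is a separate step, a 2.3-fold lower number from compound 1 to compound 3 (0.35 log units; beyond the scatter), and is not repeated here. Compound 4 keeps the bromo of compound 3, so that earlier step says nothing further about the size of the present one. Because a 2.6-fold lower number from compound 1 to compound 2 (0.41 log units; beyond the scatter) lies beyond the scatter and the present change is the same, a modest lowering of the number is expected for compound 4 in this assay, of about a 2.6-fold lower number from compound 3 to compound 4 (0.41 log units; beyond the scatter). Compound 4 is therefore estimated at 330 nM, within a range from 150 nM to 750 nM.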

Compound 4, inhibition constant: 318 nM
Estimate against measurement, compound 4: 1.0-fold (0.02 log units) above; low and high end bracket the measured number.
By their numbers in this assay, from the lowest: compound 4; then compounds 2 and 3 (each within the scatter of the next); then compound 1.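

Propanoyl in place of acetyl also lowers the number in this assay on the bromo compounds, a 2.7-fold lower number from compound 3 to compound 4 (0.43 log units; beyond the scatter), so this change is no longer known from the fluoro pair alone, and its size holds from one core to the other: the same change on two cores in this assay, a 2.6-fold lower number (0.41 log units; beyond the scatter) from compound 1 to compound 2 and a 2.7-fold lower number (0.43 log units; beyond the scatter) from compound 3 to compound 4, 1.0-fold (0.01 log units) apart, within the scatter of two such steps. Bromo in place of fluoro likewise now repeats with propanoyl in place of acetyl, a 2.3-fold lower number from compound 2 to compound 4 (0.37 log units; beyond the scatter), and its size also holds: the same change on two cores in this assay, a 2.3-fold lower number (0.35 log units; beyond the scatter) from compound 1 to compound 3 and a 2.3-fold lower number (0.37 log units; beyond the scatter) from compound 2 to compound 4, 1.0-fold (0.01 log units) apart, within the scatter of two such steps. Among these four compounds, neither change alters the size of the other, and no compound goes against this.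

From the compounds shown here alone, whether a longer chain such as butanoyl would lower the number further remains open. So does whether chloro or methoxy on the same aromatic carbon would follow bromo or fluoro.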